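The compounds below may be only part of what the source reports. "The series", "measured", "known", "first", "only" and "open" are said of these compounds alone.

Working notes on the series. Among the compounds with values here, compound 2 `CC(C)OC(=O)N1CCC(COc2ccc(N3CCN(S(=O)(=O)c4cccs4)CC3)nc2)CC1` gives the higher of the two numbers so far in a functional assay on CHO-K1 cells for agonist activity at Glucose-dependent insulinotropic receptor (Homo sapiens), read by a luciferase reporter, with a stated time of 5 h (a lower number here means that less compound is needed, a higher number that more compound is needed for the effect), at 1800 nM; compound 1 `CCCCS(=O)(=O)N1CCN(c2ccc(OCC3CCN(C(=O)OC(C)C)CC3)cn2)CC1` gives 100 nM. Within the data shown here, the one measured step is an 18-fold higher number from compound 1 to compound 2 (1.26 log units; beyond the scatter). Compound 3 `CC(C)OC(=O)N1CCC(COc2ccc(N3CCN(S(=O)(=O)N4CCCCC4)CC3)nc2)CC1` differs from compound 2 by piperidin-1-yl in place of thiophen-2-yl on a sulfonyl sulfur. Among the measured compounds shown here, no measured step covers this exact exchange; the only bearing is that compound 1, which carries a non-aromatic group on the same sulfur, gives 100 nM. A moderate move toward lower numbers is therefore expected, a 3.6-fold lower number from compound 2 to compound 3 (0.56 log units; beyond the scatter). Compound 3 is estimated at 500 nM, within 120 nM to 2500 nM.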

Compound 3, half-maximal effective concentration: 1000 nM
For compound 3 the middle estimate is 2.0-fold (0.30 log units) below the measured one, and the stated range covers the measured number.
By their numbers in this assay, from the lowest: compound 1; then compounds 3 and 2 (each within the scatter of the next).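

On the sulfonyl sulfur, the exchange of thiophen-2-yl for piperidin-1-yl gives a 1.8-fold lower number from compound 2 to compound 3 (0.26 log units; within the scatter) in this assay and does not separate the two rings. Butyl remains apart, with a 10-fold higher number from compound 1 to compound 3 (1.00 log units; beyond the scatter) on going to piperidin-1-yl, so a non-aromatic ring on this sulfur does not by itself reproduce the number of compound 1. No evidence at hand accounts for this difference. As far as these compounds go, whether a chain longer than butyl, a shorter chain such as ethyl, or an open-chain amine such as dimethylamino on this sulfur would match the number of compound 1 stays open.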